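This account rests on a few compounds, and the source may have more. Where it says the series, first, only, none or still open, it means among the compounds named here.

In a functional assay on HL-60 cells (Homo sapiens) for inhibition, read by CCK-8 assay, with a stated time of 48 h, tested at 20 uM (a higher number here means more inhibition of growth at the concentration tested, a lower number less inhibition of growth), compound 1 `N#C/C(=C\c1ccccc1OS(=O)(=O)c1ccc(Cl)cc1)C(=O)Nc1nnc(Cc2ccc(Cl)cc2)s1` gives 15% and compound 2 `Cc1ccc(Cc2nnc(NC(=O)/C(C#N)=C/c3ccccc3OS(=O)(=O)c3ccccc3[N+](=O)[O-])s2)cc1` gives 33%, the higher of the two numbers and clear of compound 1 by more than the scatter. Compound 3 `Cc1ccc(Cc2nnc(NC(=O)/C(C#N)=C/c3ccccc3OS(=O)(=O)c3ccc(Cl)cc3)s2)cc1` differs from compound 2 in one group: 4-chlorophenyl in place of 2-nitrophenyl on a sulfonyl sulfur. Compound 1, at 15%, also carries 4-chlorophenyl there, so a downward move is expected, though compound 1 differs elsewhere too and the size remains uncertain. The expected change is a number 11 percentage points lower from compound 2 to compound 3 (beyond the scatter). In this assay the estimated value for compound 3 is 22%, within a range of 8% to 38%.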

Compound 3, percent growth inhibition at one concentration: 38%
Beside the measured number, compound 3's estimate is 16 percentage points below it; low and high end bracket the measured number.
By their numbers in this assay, from the lowest: compound 1; then compounds 2 and 3 (each within the scatter of the next).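

In this assay, 4-chlorophenyl in place of 2-nitrophenyl on a sulfonyl sulfur gives only a small step (a number 5 percentage points higher from compound 2 to compound 3 (within the scatter)), so the two groups are not told apart at this position on this core. Compound 1 and compound 3 both carry 4-chlorophenyl there, and methyl in place of chloro on an aromatic carbon gives the larger step (a number 23 percentage points higher from compound 1 to compound 3 (beyond the scatter)), so 4-chlorophenyl on the sulfonyl sulfur does not by itself go with the low number of compound 1. No measurement at hand explains either step.

Open, as far as these compounds go, is how an amine or a carboxylic acid on the phenyl ring at the sulfonyl sulfur would read. Also open, from the compounds shown here alone, is how a longer chain in place of the methyl on an aromatic carbon would read.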